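From ethoxycarbonyl to hydroxymethyl on a saturated ring carbon

The compounds below may be only part of what the source reports. "The series", "measured", "known", "first", "only" and "open" are said of these compounds alone.

Measured so far in a functional assay on A549 cells (Homo sapiens) for cytotoxicity, read by MTT assay, with a stated time of 48 h; a higher number here means a weaker inhibitor, a lower number a stronger inhibitor:
- compound 1 `COc1cc([C@@H]2C[C@]2(CO)C(=O)Nc2ccccc2Cl)cc(OC)c1OC`: 4400 nM
- compound 2 `COc1cc([C@H]2C[C@]2(CO)C(=O)Nc2ccccc2Cl)cc(OC)c1OC`: 36700 nM
- compound 3 `CCOC(=O)[C@@]1(C(=O)Nc2ccccc2Cl)C[C@H]1c1cc(OC)c(OC)c(OC)c1`: 17600 nM

Among the measured compounds shown here, of these three numbers, the one for compound 3 lies in the middle. Compound 4 `COc1cc([C@@H]2C[C@@]2(CO)C(=O)Nc2ccccc2Cl)cc(OC)c1OC` has hydroxymethyl in place of ethoxycarbonyl on a saturated ring carbon. For the measured compounds named here, no measured step covers this swap directly. Going by the values given here, the only step, an 8.3-fold higher number from compound 1 to compound 2 (0.92 log units; beyond the scatter), is modest and is traced to the fact that compounds 1 and 2 differ only in the configuration as drawn. It gives the spread seen between two compounds that both carry hydroxymethyl. Compound 3 at 17600 nM falls inside that spread, so this assay is expected to show only a small move towards a lower number, within the scatter. The expected change is a 1.5-fold lower number from compound 3 to compound 4 (0.17 log units; within the scatter). For compound 4 the estimate is 12000 nM, with an expected range of 3500 nM to 40000 nM.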

Compound 4, half-maximal inhibitory concentration: 11400 nM
Compound 4: the middle estimate sits 1.1-fold (0.02 log units) above what was measured; measured number inside the range.
By their numbers in this assay, from the lowest: compound 1; then compounds 4 and 3 (each within the scatter of the next); then compound 2.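

In this assay, the direct reading of hydroxymethyl in place of ethoxycarbonyl on this saturated ring carbon is a 1.5-fold lower number from compound 3 to compound 4 (0.19 log units; within the scatter), so the two groups cannot be told apart here. Configuration does separate compounds carrying hydroxymethyl, as a 2.6-fold higher number from compound 1 to compound 4 (0.41 log units; beyond the scatter) shows, and this gap traces to one thing: the fact that compounds 1 and 4 differ only in the configuration as drawn. The mirror-image pair also separates, with a 3.2-fold lower number from compound 2 to compound 4 (0.51 log units; beyond the scatter), and here too the gap traces to one thing: the fact that compounds 2 and 4 differ only in the configuration as drawn.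

The compounds shown leave open how ethoxycarbonyl behaves in the other configurations. They also leave open whether a carboxylic acid or an amine on this saturated ring carbon would move the number further.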